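The source may hold more compounds than are shown below. What is called first, only, known or untested is meant among the compounds shown, and "the series" means these compounds.

For the measured compounds named here, compound 1 `Nc1nc(N)nc(-c2ccccc2Br)n1` is one of two compounds measured in a functional assay on the whole organism with Rattus norvegicus as the target, at a dose of 20 mg/kg by the intraperitoneal route; a lower number here means less inhibition, a higher number more inhibition at the dose given (going by the name of the read-out). In this assay compound 1 gives 26%, the lowest of the two numbers. Compound 2 `Nc1nc(N)nc(-c2ccc(Cl)cc2Br)n1` carries chloro in place of hydrogen on an aromatic carbon, and in this assay compound 2 gives 96%; the step of a number 70 percentage points higher from compound 1 to compound 2 (beyond the scatter) lies beyond the scatter. Compound 3 `COc1ccccc1-c1nc(N)nc(N)n1` has not yet been measured. It differs from compound 1 in this way: methoxy in place of bromo on an aromatic carbon. Going by the values given here, no measured step exchanges the bromo group itself, so the single known step, which adds chloro on an aromatic carbon, does not tell how trading bromo for methoxy will act. With no such guide, no step beyond the scatter is expected, and the estimate carries a wide range. Compound 3 is expected to give about 25% in this assay. The lower end for compound 3 is estimated at 0%. The upper end for compound 3 is estimated at 60%. This means an expected step of a number 1 percentage points lower from compound 1 to compound 3 (within the scatter).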

Compound 3, a percentage reported as inhibition, in the whole organism at one dose (the size of the read-out at that dose, not a potency): 1%
Compound 3: middle estimate off by 24 percentage points, on the high side, within the range that was stated.
By their numbers in this assay, from the lowest: compound 3; then compound 1; then compound 2.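

In this assay, the aromatic carbon that carries bromo in compound 1 proves sensitive to a change of the group itself: methoxy in place of bromo gives a number 25 percentage points lower from compound 1 to compound 3 (beyond the scatter), and compound 3 gives 1%, almost no inhibition at this dose. For the compounds shown here, the earlier pair showed only what adding chloro does while bromo stays in place, so this is the first sign that the bromo position also matters, at least for this one exchange. Nothing in the data given explains why the number falls with methoxy.

The compounds shown leave open how an amine or a longer chain such as ethoxy would act at this place. They also leave open whether the added chloro seen in compound 2 would raise the number for the methoxy compound as well.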